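Cytotoxicity Limits Across Three Amide Analogues

The compounds below may be only part of what the source reports. "The series", "measured", "known", "first", "only" and "open" are said of these compounds alone.

Compound 3 `CCOC(=O)CCCCCOc1cccc(CN(C(=O)c2ccc(-c3cccc(OCC)c3)cc2)C(C)C)c1` is one of three analogues measured in an ADME assay on HepG2 cells (Homo sapiens) for cytotoxicity, read by CellTiter-Glo and resazurin assay, with a stated time of 72 h; a lower number here means that less compound is needed, a higher number that more compound is needed for the effect. In this assay compound 3 reaches only a limit, > 22300 nM. Compound 1 `CCOC(=O)CCCCCOc1cccc(CN(C(=O)c2ccc(-c3ccc4ccccc4c3)cc2)C(C)C)c1` carries the naphthalen-2-yl group instead. In this assay compound 1 likewise reaches only a limit, > 26000 nM. Compound 2 `CCOC(=O)CCCCCOc1cccc(CN(C(=O)c2ccc(-c3cccc(C(C)=O)c3)cc2)C(C)C)c1` carries the 3-acetylphenyl group. In this assay compound 2 also reaches only a limit, > 26000 nM. Compound 3 thus stands at the limit of > 22300 nM in this assay, at which 1 of the 3 values shown sits. The two remaining values sit at the limit of > 26000 nM in this assay, at which 2 of the 3 values shown sit. The steps between the measured compounds, a step that the two limits leave unreadable from compound 1 to compound 2, a step that the two limits leave unreadable from compound 1 to compound 3 and a step that the two limits leave unreadable from compound 2 to compound 3, cannot be sized; every value involved is a limit, so neither direction nor magnitude can be read from them.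

Compound 4 `CCOC(=O)CCCCCOc1cccc(CN(C(=O)c2ccc(-c3cc(OC)cc(OC)c3)cc2)C(C)C)c1` brings the change (3,5-dimethoxyphenyl in place of 3-ethoxyphenyl on an aromatic carbon). Among the measured compounds shown here, no measured step bears on this change in this assay with a readable size, and all three analogues sit at limits, so no direction can be drawn from them. Compound 4 is therefore expected to sit at a limit as well, with an estimated step that the limit leaves unreadable from compound 3 to compound 4 that is expected to lie within the scatter. The estimate for compound 4 is 30000 nM, expected to fall between 18000 nM and 60000 nM.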

Compound 4, half-maximal effective concentration: > 26000 nM
Compound 4 ended at the assay's limit (the forecaster's own chance of this, stated with the estimate: 85%); the middle value lies beyond the limit too.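

In this assay compound 4 also reaches only a limit, > 26000 nM. Among the compounds shown here, no step from compound 1, compound 2 or compound 3 to compound 4 can be read, in either size or direction. The compounds shown leave open at what concentration any of them would reach the half-maximal effect, and whether the exchanged group makes any difference.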